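Swapping the aryl ether for a cyanobenzyl group in the furan series

The source may hold more compounds than are shown below. What is called first, only, known or untested is meant among the compounds shown, and "the series" means these compounds.

Compound 1 `COc1ccc(Oc2ccc3c(NCCCNCc4cccc(OC)c4O)ccnc3c2)cc1` gives 9.28 in a physicochemical assay for acid dissociation. Compound 2 `COc1cccc(CNCCCNc2ccnc3cc(Cc4ccc(C#N)cc4)ccc23)c1O` carries 4-cyanobenzyl in place of 4-methoxyphenoxy on an aromatic carbon, and in this assay compound 2 gives 9.47, so that a number 0.19 log units higher from compound 1 to compound 2 (within the scatter). Compound 3 `COc1ccc(Oc2ccc3c(NCCCNCc4ccco4)ccnc3c2)cc1` differs from compound 1 in its core by furan-2-yl in place of 2-hydroxy-3-methoxyphenyl on a saturated chain carbon bound to an amine nitrogen, and in this assay compound 3 gives 9.28, which means no change at the digits printed from compound 1 to compound 3 (within the scatter). Compound 4 `N#Cc1ccc(Cc2ccc3c(NCCCNCc4ccco4)ccnc3c2)cc1` has not been measured; it differs from compound 3 by 4-cyanobenzyl in place of 4-methoxyphenoxy on an aromatic carbon, the same change that leads from compound 1 to compound 2. For compound 4 the expected step is a number 0.19 log units higher from compound 3 to compound 4 (within the scatter), resting on the earlier step of a number 0.19 log units higher from compound 1 to compound 2 (within the scatter) and on the shared place of the change. Compound 4 is therefore estimated at 9.47 in this assay, expected between 9.2 and 9.75.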

Compound 4, acid dissociation constant: 9.47
Estimate against measurement, compound 4: no gap at the digits printed; the range from low to high includes it.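

In this assay, 4-cyanobenzyl in place of 4-methoxyphenoxy gives the same step on the furan-2-yl core (a number 0.19 log units higher from compound 3 to compound 4 (within the scatter)) as on the core of compound 1 (a number 0.19 log units higher from compound 1 to compound 2 (within the scatter)), while furan-2-yl in place of 2-hydroxy-3-methoxyphenyl again gives a step within the scatter (no change at the digits printed from compound 2 to compound 4 (within the scatter)). This shows that the change carried across these two cores without a step beyond the scatter, but it does not show that the change itself has a real effect on this read-out or that a larger step would carry over. No supporting measurement bears on why these numbers agree.

The compounds shown leave open whether a carboxylic acid in place of 4-cyanobenzyl on that aromatic carbon would give a step beyond the scatter. They also leave open whether such a step would carry between these cores.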